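The source may hold more compounds than are shown below. What is called first, only, known or untested is meant among the compounds shown, and "the series" means these compounds.

Measured so far:
compound 1 `Cn1cc(NC(=O)c2cccc(NS(=O)(=O)c3ccccc3)c2)cn1` — 41200 nM
compound 2 `O=C(Nc1cnn(-c2ccccc2)c1)c1cccc(NS(=O)(=O)c2ccccc2)c1` — 4320 nM

Both were run in a functional assay on MCF7 cells (Homo sapiens) for inhibition, read by MTT assay, with a stated time of 48 h; a higher number here means a weaker inhibitor, a lower number a stronger inhibitor. Going by the values given here, compound 2 stands lowest of the two numbers; its nearest neighbour is compound 1, and the single step between them, a 9.5-fold lower number from compound 1 to compound 2 (0.98 log units; beyond the scatter), lies beyond the scatter.

Compound 3 `Cc1ccc(-n2cc(NC(=O)c3cccc(NS(=O)(=O)c4ccccc4)c3)cn2)cc1` is not yet measured. It differs from compound 2 by methyl in place of hydrogen on an aromatic carbon; read one bond further out, the phenyl on the aromatic nitrogen becomes 4-methylphenyl. Among the compounds with values here, the one measured step bears on this only loosely: the step from compound 1 to compound 2 exchanged methyl for phenyl on an aromatic nitrogen, a larger alteration than a single methyl on a ring carbon, and no pair here probes a methyl on that phenyl itself. The step expected for compound 3 is therefore a 1.2-fold lower number from compound 2 to compound 3 (0.09 log units; within the scatter), not expected to go beyond the scatter in either direction. Compound 3 is estimated at 3500 nM, with a range from 1200 nM to 11000 nM.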

Compound 3, half-maximal inhibitory concentration: 1690 nM
Compound 3: the middle estimate sits 2.1-fold (0.32 log units) above what was measured; measured number inside the range.
By their numbers in this assay, from the lowest: compound 3; then compound 2; then compound 1.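

In this assay, the phenyl on the aromatic nitrogen is shown to be sensitive to substitution: methyl in place of hydrogen on an aromatic carbon, para to a large group, gives a 2.6-fold lower number from compound 2 to compound 3 (0.41 log units; beyond the scatter) and so moves the number beyond the scatter with a single added carbon. The earlier compounds shown here left that phenyl unsubstituted and could not show this. Replacing the methyl on the aromatic nitrogen with 4-methylphenyl gives a 24-fold lower number from compound 1 to compound 3 (1.39 log units; beyond the scatter) in total, so the two changes on this side of the molecule both lead to a lower number; no data accompany the series that would explain either step.

From the compounds shown here alone, whether the lower number is specific to methyl remains open, since a chlorine, a methoxy or an amine at the same carbon could give a different result. The compounds shown also leave open whether a methyl elsewhere on that phenyl would have a similar effect.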